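One Change, Two Cores: Estimating a Deacetylase Inhibitor

The source may hold more compounds than are shown below. What is called first, only, known or untested is meant among the compounds shown, and "the series" means these compounds.

Four compounds are compared here, two of them with a result and two without. Compound 1 `COc1cc(C(=O)c2ccc3c(ccn3S(=O)(=O)c3cccc(/C=C/C(=O)NO)c3)c2)cc(OC)c1OC` and compound 2 `COc1ccc(C(=O)c2ccc3c(ccn3S(=O)(=O)c3cccc(/C=C/C(=O)NO)c3)c2)cc1` share one core and were both tested in an assay on isolated protein for inhibition of polyamine deacetylase HDAC10 (Homo sapiens); on this read-out higher numbers stand for weaker inhibition and lower numbers for stronger inhibition. For compound 1 the result is not a number but a limit of the assay, > 100000 nM (the limit of > 100000 nM in this assay, at which 1 of the 3 values shown sits). Compound 2 gives 5890 nM in this assay. The change between them is 4-methoxyphenyl in place of 3,4,5-trimethoxyphenyl on a carbonyl carbon and it produced an at least 16-fold lower number from compound 1 to compound 2 (1.22 log units; beyond the scatter).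

Compound 3 `COc1cc(C(=O)c2ccc3c(ccn3Cc3ccc(/C=C/C(=O)NO)cc3)c2)cc(OC)c1OC` and compound 4 `COc1ccc(C(=O)c2ccc3c(ccn3Cc3ccc(/C=C/C(=O)NO)cc3)c2)cc1` are built on a second core; how that core differs from the core of compound 1 is not broken down here. For compound 3 the result in this assay is recorded as "not determined" (no result reported). Going by the values given here, the change from compound 3 to compound 4 is 4-methoxyphenyl in place of 3,4,5-trimethoxyphenyl on a carbonyl carbon, the same change as the one measured between compound 1 and compound 2, made at the same kind of place.

Since compound 3 has no number, the expectation for compound 4 rests only on the measured pair: the same change gave an at least 16-fold lower number from compound 1 to compound 2 (1.22 log units; beyond the scatter), and compound 2 with the smaller group reached 5890 nM. On that basis compound 4 is estimated to reach about 3000 nM in this assay, with an expected range from 500 nM to 20000 nM.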

Compound 4, half-maximal inhibitory concentration: 7050 nM
Beside the measured number, compound 4's estimate is 2.4-fold (0.37 log units) below it; measured number inside the range.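

No new step can be read here: compound 3 has no reported result in this assay, so compound 4, at 7050 nM, has no measured partner for comparison. Still open is whether 4-methoxyphenyl in place of 3,4,5-trimethoxyphenyl does as much on the second core as on the first, and the full size of that change on the first, because compound 1 gives only a limit: the limit of > 100000 nM in this assay, at which 1 of the 4 values shown sits.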